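This account rests on a few compounds, and the source may have more. Where it says the series, first, only, none or still open, it means among the compounds named here.

Measured in a functional assay on DLD-1 cells (Homo sapiens) for inhibition, read by MTT assay, with a stated time of 72 h; a lower number here means a stronger inhibitor, a higher number a weaker inhibitor:

- compound 1 `COc1cc(Oc2cccc(Nc3ccccc3)c2)cc(OC)c1CNCCNC(C)=O`: 6010 nM
- compound 2 `COc1cc(Oc2cccc(Nc3ccccc3)c2)cc(OC)c1CN[C@H](C)c1ccccc1`: 8570 nM
- compound 3 `COc1cc(Oc2cccc(Nc3ccccc3)c2)cc(OC)c1CNCc1ccc(Cl)cc1`: 3740 nM

Among the compounds with values here, compound 3 has the lowest number of the three, but its gap to compound 1 is within the scatter; only the step of a 2.3-fold lower number from compound 2 to compound 3 (0.36 log units; beyond the scatter) is beyond it. The other steps, a 1.4-fold higher number from compound 1 to compound 2 (0.15 log units; within the scatter) and a 1.6-fold lower number from compound 1 to compound 3 (0.21 log units; within the scatter), are within the scatter. Compound 4 `CCN1CCN(Cc2c(OC)cc(Oc3cccc(Nc4ccccc4)c3)cc2OC)CC1` differs from compound 3 by 4-ethylpiperazin-1-yl in place of (4-chlorobenzyl)amino on a saturated chain carbon bound to an aromatic carbon. Every measured step also swaps the group on the amine nitrogen, and none moved the number far, so no step beyond the scatter is expected in this assay from compound 3 to compound 4. The expected step is a 1.2-fold higher number from compound 3 to compound 4 (0.08 log units; within the scatter). Compound 4 is thus estimated at 4500 nM, within a range from 1500 nM to 14000 nM.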

Compound 4, half-maximal inhibitory concentration: > 20000 nM
Compound 4: only a limit was reported; the forecaster's own chance of this, stated with the estimate: 5%; middle value at least 4.4-fold (0.64 log units) away from the limit.
By their numbers in this assay, from the lowest: compounds 3, 1 and 2 (each within the scatter of the next, the first and the last beyond it). At a limit, above all of these: compound 4.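

In this assay, the group on a saturated chain carbon bound to an aromatic carbon now proves able to move the number clearly: 4-ethylpiperazin-1-yl gives an at least 5.3-fold higher number from compound 3 to compound 4 (0.72 log units; beyond the scatter), along with an at least 3.3-fold higher number from compound 1 to compound 4 (0.52 log units; beyond the scatter) and an at least 2.3-fold higher number from compound 2 to compound 4 (0.36 log units; beyond the scatter). Compound 4 is also the only one of the four with this nitrogen held in a ring. These steps have only a lower bound, as compound 4 stands at a limit of the assay: the limit of > 20000 nM in this assay, at which 1 of the 4 values shown sits.

Whether the ring, the second ring nitrogen or the ethyl group accounts for the change stays open. Piperidine, morpholine or unsubstituted piperazine at this place would separate these.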